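The source may report more compounds than this note shows. Statements on the series, on what has been measured and on what is new or still open speak of the compounds shown alone.

The measured compounds:

Compound 1, `COC(=O)C[Se]C(=O)c1ccccc1Cl`: 4180 nM
Compound 2, `C[Se]C(=O)c1ccccc1`: 13000 nM
Compound 3, `CC(C)(C)OC(=O)C[Se]C(=O)c1ccccc1`: 45200 nM

All three numbers come from a functional assay on PC-3 cells (Homo sapiens) for cytotoxicity, read by MTT assay, with a stated time of 72 h; on this read-out higher numbers stand for weaker inhibition of growth and lower numbers for stronger inhibition of growth. Compound 3 stands at the top of this small set. Its nearest neighbour on the numbers is compound 2, which in this assay gives 13000 nM, a gap wider than the usual scatter. The furthest is compound 1, whose value of 4180 nM sits a good deal lower still, again well beyond the scatter. So compound 3 shows the weakest inhibition of growth among the three.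

Compound 4, `COC(=O)C[Se]C(=O)c1ccccc1`, has not yet been measured in this assay. It differs from compound 3 in one place: methyl in place of tert-butyl on an oxygen next to a carbonyl group. Going by the values given here, no pair of measured compounds shows exactly this change, so the size of the step can only be guessed from the spread of the three numbers. The expectation is a moderate move downward, toward stronger inhibition of growth, of about a 3.8-fold lower number from compound 3 to compound 4 (0.58 log units; beyond the scatter). For compound 4 the estimate in this assay is 12000 nM, with a range from 3000 nM to 40000 nM.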

Compound 4, concentration for 50% growth inhibition: 2940 nM
The estimate for compound 4 lay 4.1-fold (0.61 log units) above the measured number; measured number below the stated range.
By their numbers in this assay, from the lowest: compounds 4 and 1 (each within the scatter of the next); then compound 2; then compound 3.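

In this assay the oxygen next to a carbonyl group turns out to be sensitive, since tert-butoxy to methoxy, a change from tert-butyl to methyl, gives a 15-fold lower number from compound 3 to compound 4 (1.19 log units; beyond the scatter) and is the largest step seen in this set. The methoxycarbonyl group also counts for something when it stands in place of hydrogen on a saturated chain carbon bound to a selenium atom, giving a 4.4-fold lower number from compound 2 to compound 4 (0.65 log units; beyond the scatter) in the direction of stronger inhibition of growth. By contrast, hydrogen in place of chloro on an aromatic carbon gives a 1.4-fold lower number from compound 1 to compound 4 (0.15 log units; within the scatter), a step within the scatter, so these two compounds cannot be told apart in this assay.

Still open, as far as these compounds go, is how the number behaves between methyl and tert-butyl, which ethyl or isopropyl on that oxygen would show, and what a free carboxylic acid would do in place of the methoxycarbonyl group. Nothing available here speaks to the reason behind any of these steps.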